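The source may hold more compounds than are shown below. What is called first, only, known or untested is meant among the compounds shown, and "the series" means these compounds.

Measured in a functional assay on MDA-MB-231 cells (Homo sapiens) for inhibition, read by crystal violet staining, with a stated time of 24 h; a higher number here means a weaker inhibitor, a lower number a stronger inhibitor:

Compound 1 `CC(=O)OC[C@H]1O[C@H]2O[C@H]3[C@H](OC(C)CCCCCC/C=C\CCCCCCCC(=O)O[C@H]1[C@H](O)[C@H]2O)O[C@H](CO)[C@@H](O)[C@@H]3O` gives 15000 nM.
Compound 2 `CC(CCCCCC/C=C\CCCCCCCC(=O)O)O[C@@H]1O[C@H](CO)[C@@H](O)[C@H](O)[C@H]1O[C@@H]1O[C@H](CO)[C@@H](O)[C@H](O)[C@H]1O` gives 80000 nM.
Compound 3 `CC(=O)OC[C@H]1O[C@H]2OC(C)/C=C/C/C=C/C/C=C\CCCCCCCC(=O)O[C@H]3[C@H](O)[C@@H](O)[C@H](O[C@@H]2[C@@H](O)[C@@H]1O)O[C@@H]3COC(C)=O` gives 30000 nM.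

Compound 1 holds the lowest number of the three. Its gap to compound 3 lies within the usual scatter of this assay, so no order between those two is claimed. Its gap to compound 2 lies beyond the scatter, so compound 2 stands as a weaker inhibitor than compound 1 on these numbers. Within the data shown here, no single-site step between measured compounds is available to calibrate the change below.

Compound 4 `CC(=O)C[C@H]1O[C@H]2OC(C)CCCCCC/C=C\CCCCCCCC(=O)O[C@H]3[C@H](O)[C@@H](O)[C@H](O[C@@H]2[C@@H](O)[C@@H]1O)O[C@@H]3COC(C)=O` differs from compound 1 in one place: acetyl in place of hydroxy on a saturated chain carbon bound to a saturated ring carbon. The change sits on a saturated chain carbon bound to a saturated ring carbon, at the edge of the shared core.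

Without a measured step of this kind, the expected step from compound 1 to compound 4 is estimated as small, in no firm direction, and not beyond the scatter: no change at the digits printed from compound 1 to compound 4 (within the scatter). Compound 4 is thus expected to give about 15000 nM, in the range 6000 nM to 40000 nM.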

Compound 4, half-maximal inhibitory concentration: 15000 nM
The estimate for compound 4 equals the measured number at the digits printed; the measured number falls inside the stated range.
By their numbers in this assay, from the lowest: compounds 1, 4 and 3 (each within the scatter of the next); then compound 2.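

In this assay, the series now has its first single-site step, which reads no change at the digits printed from compound 1 to compound 4 (within the scatter) with acetyl in place of hydroxy on a saturated chain carbon bound to a saturated ring carbon. At this place, then, the hydroxy group and its hydrogen-bond donor can give way to the larger acetyl, which has no such donor, without a shift beyond the scatter. No supporting measurement is available to explain why the number holds.

This single step cannot show whether the place accepts any group or only these two, so an amine or a carboxylic acid at the same carbon could still move the number in either direction. From the compounds shown here alone, whether a longer chain ending in a ketone carbonyl would behave as the 2-oxopropyl group does also remains open.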